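Swapping a Methyl for an Ester on the Benzyl Ring

The compounds below may be only part of what the source reports. "The series", "measured", "known", "first", "only" and "open" are said of these compounds alone.

Compound 1 `O=[N+]([O-])c1ccccc1COc1ccc(OCCOCCNC2CCCC2)cc1` gives 5370 nM.
Compound 2 `CCOc1ccc(OCCOCCNC2CCCC2)cc1` gives 90500 nM.
Compound 3 `Cc1ccc(COc2ccc(OCCOCCNC3CCCC3)cc2)cc1` gives 17200 nM.

All three were tested in a functional assay on SK-OV-3 cells (Homo sapiens) for inhibition, read by CCK-8 assay, with a stated time of 70 h; a higher number here means a weaker inhibitor, a lower number a stronger inhibitor. Compound 3 stands second highest of the three numbers: a 3.2-fold higher number from compound 1 to compound 3 (0.51 log units; beyond the scatter), while a 5.3-fold lower number from compound 2 to compound 3 (0.72 log units; beyond the scatter). Compound 4 `COC(=O)c1ccc(COc2ccc(OCCOCCNC3CCCC3)cc2)cc1` differs from compound 3 by methoxycarbonyl in place of methyl on an aromatic carbon. Neither measured step touches a substituent on that ring; each swaps the whole group bound to the saturated chain carbon, so they bear on this change only loosely. The largest of them, a 17-fold higher number from compound 1 to compound 2 (1.23 log units; beyond the scatter), shows that this region does move the numbers in this assay. Without a direct precedent, a step of about the usual scatter is expected, a 1.4-fold lower number from compound 3 to compound 4 (0.16 log units; within the scatter). Compound 4 is therefore estimated at 12000 nM, within a range from 4000 nM to 36000 nM.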

Compound 4, half-maximal inhibitory concentration: 6990 nM
The estimate for compound 4 lay 1.7-fold (0.23 log units) above the measured number; low and high end bracket the measured number.
By their numbers in this assay, from the lowest: compounds 1 and 4 (each within the scatter of the next); then compound 3; then compound 2.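

Here a substituent on this ring changes for the first time with all else held constant: methoxycarbonyl in place of methyl gives a 2.5-fold lower number from compound 3 to compound 4 (0.39 log units; beyond the scatter), a modest gain. Putting 4-(methoxycarbonyl)phenyl in place of methyl on the chain carbon gives a large step, a 13-fold lower number from compound 2 to compound 4 (1.11 log units; beyond the scatter), whereas the step from 2-nitrophenyl, a 1.3-fold higher number from compound 1 to compound 4 (0.11 log units; within the scatter), leaves compound 1 and compound 4 indistinguishable. Nothing shown here explains why the number moves. Going by these compounds, whether a carboxylic acid or an amine in the same place would lower the number further remains open.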